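A few compounds are considered here, and "the series" means these few. Any claim that something is new, unique, unknown or untested is made for them only; others in the source may bear on it.

Going by the values given here, in a functional assay on HCT-116 cells (Homo sapiens) for antiproliferative activity, read by MTT assay (a lower number here means a stronger inhibitor, a higher number a weaker inhibitor), only two close relatives of compound 3 have been measured. Compound 1 `Cc1cccc(/C=N/Nc2ncc3c(n2)n(C2CCCC2)c(=O)c(=O)n3C)c1` reads > 100000 nM, which is a limit of the assay and not a number. Among the compounds with values here, compound 2 `Cn1c(=O)c(=O)n(C2CCCC2)c2nc(N/N=C/c3cccc(O)c3)ncc21`, with hydroxy in place of methyl on an aromatic carbon, gives 37200 nM, the only true number so far. On these data alone, the measured step, an at least 2.6-fold lower number from compound 1 to compound 2 (0.42 log units; beyond the scatter), lies beyond the scatter, but its full size remains open since one end is a limit.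

Compound 3 `Cn1c(=O)c(=O)n(C2CCCC2)c2nc(N/N=C/c3ccc(F)cc3F)ncc21` keeps the shared core and carries 2,4-difluorophenyl in place of 3-hydroxyphenyl on a carbon with a double bond to nitrogen. The hydroxy is gone, so compound 3, like compound 1, carries none. Within the data shown here, the one measured step that bears on this is an at least 2.6-fold lower number from compound 1 to compound 2 (0.42 log units; beyond the scatter), where the number fell as hydroxy arrived, so the number is expected to rise here, towards weaker inhibition. Among the measured compounds shown here, no fluorinated compound has been measured, so this guide is thin. The expected change is modest, a 2.0-fold higher number from compound 2 to compound 3 (0.30 log units; within the scatter). For compound 3 the estimate is 75000 nM, with an expected range from 25000 nM to 150000 nM.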

Compound 3, half-maximal inhibitory concentration: 19800 nM
Estimate against measurement, compound 3: 3.8-fold (0.58 log units) above; measured number outside the range, below it.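

In this assay, 2,4-difluorophenyl on a carbon with a double bond to nitrogen gives a 1.9-fold lower number from compound 2 to compound 3 (0.27 log units; within the scatter), so the two compounds cannot be told apart, and a hydroxy on this ring is not required for a reading at this level: the entering group has 0 hydrogen-bond donors, and the earlier step alone could not show this. Against 3-methylphenyl, the same group gives an at least 5.0-fold lower number from compound 1 to compound 3 (0.70 log units; beyond the scatter), so two rings without a hydroxy can read differently, and the absence of a hydroxy does not by itself put a compound at the weak end of this short series. Compound 1 stands at a limit of the assay and not at a number, so this step gives only a lower bound on the size of the change: the limit of > 100000 nM in this assay, at which 1 of the 3 values shown sits.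

Still open is whether both fluorines matter, since the compounds shown do not separate them, and a plain phenyl or a ring with a single fluorine would address that. On these data alone, how a 3-aminophenyl or a ring carrying a carboxylic acid would read at this place also remains unknown.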